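The source may report more compounds than this note shows. Statements on the series, on what has been measured and on what is new or still open speak of the compounds shown alone.

Compound 3 `Cc1ccc(-c2ccc3ncc(-c4noc(C)n4)cc3c2)cc1` carries a 4-methylphenyl group on the shared core. In a functional assay on RD cells (Homo sapiens) for inhibition, read by luminescence and ATP content, with a stated time of 72 h (a higher number here means that more compound is tolerated, a lower number that less compound is tolerated), compound 3 gives only a limit, > 7400 nM. Its two measured neighbours are likewise known only by limits. Compound 1 `Cc1nc(-c2cnc3ccc(-c4ccc(N)nc4)cc3c2)no1` bears 6-aminopyridin-3-yl where compound 3 bears 4-methylphenyl. In this assay compound 1 reaches only a limit of > 7400 nM. Compound 2 `CCCCc1ccc(-c2ccc3ncc(-c4noc(C)n4)cc3c2)cc1`, which carries a propyl on the saturated chain carbon bound to an aromatic carbon, gives in this assay a limit of > 2500 nM. The step that the two limits leave unreadable from compound 1 to compound 3 and the step that the two limits leave unreadable from compound 2 to compound 3 therefore cannot be sized; what is known amounts to the limit of > 2500 nM in this assay, at which 1 of the 3 values shown sits, and (the limit of > 7400 nM in this assay, at which 2 of the 3 values shown sit). Compound 4 `COc1ccc(-c2ccc3ncc(-c4noc(C)n4)cc3c2)cc1` differs from compound 3 by methoxy in place of methyl on an aromatic carbon. Within the data shown here, no measured step bears on this change, and all three values sit at limits, so no shift beyond the scatter in this assay can be expected in either direction. Compound 4 is therefore expected to give in this assay about 10000 nM, within 5000 nM to 30000 nM, most probably again reported only as a limit. The estimated step that the limit leaves unreadable from compound 3 to compound 4 is thus expected to be negligible.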

Compound 4, half-maximal cytotoxic concentration: > 66700 nM
Compound 4: a limit, no number; the forecaster's own chance of this, stated with the estimate: 85%; middle value at least 6.6-fold (0.82 log units) from the limit.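

In this assay compound 4 is known only by a limit, as are compound 1, compound 2 and compound 3, and none of the steps from those three to compound 4 can be read. The compounds shown leave open whether methoxy in place of methyl changes the half-maximal cytotoxic concentration at all.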